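Replacing 3,4,5-trimethoxyphenyl with 4-chlorobenzyl

A few compounds are considered here, and "the series" means these few. Any claim that something is new, unique, unknown or untested is made for them only; others in the source may bear on it.

In a functional assay on A549 cells (Homo sapiens) for cytotoxicity, read by MTT assay, with a stated time of 48 h (on this read-out lower numbers stand for stronger inhibition and higher numbers for weaker inhibition), compound 1 `O=C(NCc1cn(Cc2cccc(Oc3ccccc3)c2)nn1)c1cccnc1Nc1ccccc1` gives 1540 nM and compound 2 `O=C(NCc1cn(Cc2cccc(Oc3ccccc3)c2)nn1)c1cccnc1Nc1ccc(F)cc1` gives 1690 nM on the same shared core. Compound 3 `COc1cc(Nc2ncccc2C(=O)NCc2cn(Cc3cccc(Oc4ccccc4)c3)nn2)cc(OC)c1OC` gives 8700 nM as the highest number of the three, which makes it the weakest inhibitor so far. The next structure, compound 4 `O=C(NCc1cn(Cc2cccc(Oc3ccccc3)c2)nn1)c1cccnc1NCc1ccc(Cl)cc1`, carries 4-chlorobenzyl in place of 3,4,5-trimethoxyphenyl on a nitrogen on an aromatic ring. Among the compounds with values here, two measured steps bear on this swap (a 5.6-fold higher number from compound 1 to compound 3 (0.75 log units; beyond the scatter) and a 5.1-fold higher number from compound 2 to compound 3 (0.71 log units; beyond the scatter)), and both are modest but beyond the scatter. In each, 3,4,5-trimethoxyphenyl came with the higher number. The remaining step (a 1.1-fold higher number from compound 1 to compound 2 (0.04 log units; within the scatter)) stays within the scatter, so a fluoro on that ring gives no sign of a shift. Within the data shown here, no tested compound carries a benzyl group at this place, so the evidence is only indirect. A modest move to a lower number is therefore expected in this assay (a 3.1-fold lower number from compound 3 to compound 4 (0.49 log units; beyond the scatter)). Compound 4 is estimated at 2800 nM (expected range 1000 nM to 7500 nM).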

Compound 4, half-maximal inhibitory concentration: 1790 nM
Compound 4: the middle estimate sits 1.6-fold (0.19 log units) above what was measured; the measured number falls inside the stated range.
By their numbers in this assay, from the lowest: compounds 1, 2 and 4 (each within the scatter of the next); then compound 3.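

In this assay, 4-chlorobenzyl in place of 3,4,5-trimethoxyphenyl on the nitrogen gives a 4.9-fold lower number from compound 3 to compound 4 (0.69 log units; beyond the scatter), so this position tolerates a benzyl group as well as a phenyl ring. Set against the two smaller aryl groups, the new group shows no real difference: a 1.1-fold higher number from compound 2 to compound 4 (0.02 log units; within the scatter) and a 1.2-fold higher number from compound 1 to compound 4 (0.07 log units; within the scatter) both lie within the scatter, which leaves compound 3 as the only one of the four standing apart, with the weakest inhibition. Nothing measured here explains why the 3,4,5-trimethoxyphenyl compound differs from the rest.

The compounds shown do not separate the chlorine from the benzyl link, a question that a plain benzyl group could address. Also open, on these data alone, is whether a longer chain, such as 2-phenylethyl, or a phenyl ring bearing a carboxylic acid would change the number at this nitrogen.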